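The source may report more compounds than this note shows. Statements on the series, on what has been measured and on what is new or still open speak of the compounds shown alone.

Measured so far:
- compound 1, `Cc1cc(Nc2nc(NCc3cc(F)ccc3F)nc3ccccc23)n[nH]1`, in an assay for inhibition of BDNF/NT-3 growth factors receptor (Homo sapiens), read by HTRF, with a stated time of 40 min, in the presence of a further agent that is not named here (on this read-out higher numbers stand for weaker inhibition and lower numbers for stronger inhibition), gives 6 nM
- compound 2, `Fc1ccc(CNc2nc(Nc3cc(C4CC4)[nH]n3)c3ccccc3n2)c(F)c1`, in this assay gives 28 nM
- compound 3, `Cc1cc(Nc2nc(NCc3ccc(F)cc3F)nc3cc(Cl)ccc23)n[nH]1`, in this assay gives 24 nM

Compound 3 stands second highest of the three numbers in this assay. Its nearest neighbour is compound 2, whose value lies within the usual scatter of that of compound 3, so no order between the two is read. Compound 1 lies furthest off, with a lower number than compound 3, and that gap is beyond the scatter.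

Compound 4, `Cc1cc(Nc2nc(NCc3ccc(F)cc3F)nc3cc(C(F)(F)F)ccc23)n[nH]1`, has not yet been measured. It differs from compound 3 in one place: trifluoromethyl in place of chloro on an aromatic carbon. Among the compounds with values here, no measured pair in this set carries the same exchange, so there is no step to lean on.

The expectation for compound 4 rests only on compound 3 and its value 24 nM in this assay. The step from compound 3 to compound 4 is expected to be small, a 1.3-fold higher number from compound 3 to compound 4 (0.10 log units; within the scatter), and not beyond the scatter in either direction. The estimate for compound 4 in this assay is therefore 30 nM, with a range from 12 nM to 80 nM.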

Compound 4, half-maximal inhibitory concentration: 6.6 nM
The estimate for compound 4 lay 4.5-fold (0.66 log units) above the measured number; the whole stated range lies above it.
By their numbers in this assay, from the lowest: compounds 1 and 4 (each within the scatter of the next); then compounds 3 and 2 (each within the scatter of the next).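

In this assay, within the data shown here, trifluoromethyl in place of chloro on this aromatic carbon gives a 3.6-fold lower number from compound 3 to compound 4 (0.56 log units; beyond the scatter), the first step between measured compounds that differ in one place. This position therefore responds to the exchange, and the larger group, with four heavy atoms where chloro has one, brings no loss in this assay. No measurement at hand bears on what lies behind the step, so it stands as an observation on a single pair.

Going by these compounds, whether the gain is particular to trifluoromethyl remains open, as a nitrile, a methoxy group or an amine on the same carbon would be needed to show how far the position tolerates other groups. Also open, on these data alone, is whether the exchange keeps its size when other parts of the compound change.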